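A few compounds are considered here, and "the series" means these few. Any claim that something is new, unique, unknown or untested is made for them only; others in the source may bear on it.

Compound 1 `CCc1oc2cc(OC)ccc2c1C(=O)c1ccc(OC)cc1` and compound 2 `CCc1cc2c(C(=O)c3ccc(OC)cc3)cc(OC)cc2o1` are built from the same atoms joined differently; how their two cores differ is not broken down here. In an assay for inhibition of solute carrier family 22 member 12 (Homo sapiens), read by scintillation counting, with a stated time of 60 min, tested at 50 uM (a higher number here means more inhibition at the concentration tested (going by the name of the read-out), a lower number less inhibition), compound 1 gives 6.2%, and in this assay compound 2 gives 1.5%, a pair of values that lie within the usual scatter of each other.

Compound 3 `CCc1oc2cc(OC)ccc2c1C(=O)c1ccc(O)cc1` carries the core of compound 1 with one change, (hydrogen in place of methyl on an oxygen on an aromatic ring). In this assay compound 3 gives 92.7%. This single change produced a step of a number 86.5 percentage points higher from compound 1 to compound 3 (beyond the scatter), the one large movement among the three measured compounds.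

Compound 4 `CCc1cc2c(C(=O)c3ccc(OC)cc3)cc(O)cc2o1` has not yet been measured. It stands to compound 2 as compound 3 stands to compound 1: the change is hydrogen in place of methyl on an oxygen on an aromatic ring, and the words describing the place are the same in both cases, so it is the same change. Since the two cores are not broken down here, the expectation rests on a single measured step.

On that basis the step from compound 2 to compound 4 is expected to be a number 53.5 percentage points higher from compound 2 to compound 4 (beyond the scatter), resting on the measured step of a number 86.5 percentage points higher from compound 1 to compound 3 (beyond the scatter). Compound 4 is therefore estimated to give 55% in this assay, with an expected range from 15% to 90%, the width reflecting that the change here sits on a core whose relation to the core of compound 1 is not counted out.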

Compound 4, a percentage reported as inhibition, at one concentration (the size of the read-out at that concentration, not a potency): 12.4%
For compound 4 the middle estimate is 42.6 percentage points above the measured one, and the stated range ends above it.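

On the core of compound 2, the change from methoxy to hydroxy gives a number 10.9 percentage points higher from compound 2 to compound 4 (beyond the scatter) in this assay, a modest step that points the same way as the large one on the core of compound 1, but the two steps differ clearly in size: the same change on two cores in this assay, a number 86.5 percentage points higher (beyond the scatter) from compound 1 to compound 3 and a number 10.9 percentage points higher (beyond the scatter) from compound 2 to compound 4, 75.6 percentage points apart, beyond the scatter of two such steps. So in this series the direction of the change held across the two cores, while its size did not carry from one to the other, and a step measured on one core gave no reliable measure of the step on the other. The two pairs do not show why the steps differ, since the words "on an oxygen on an aromatic ring" fit both changes without showing whether the two sites are equivalent, and two pairs cannot establish a rule for other cores.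

The compounds shown leave open what hydroxy would do at the remaining methoxy of compound 3 or compound 4, and whether a carboxylic acid or an amine in its place would behave as hydroxy does. They also leave open whether a longer chain in place of the ethyl would alter the size of either step.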